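The compounds below may be only part of what the source reports. "The series", "measured", "known", "first", "only" and "open" are said of these compounds alone.

Measured compounds:
compound 1 `O=C(O)CCNC(=O)c1ccc(C(Oc2ccc(-n3cc(C(F)(F)F)cn3)cc2)C2CCCC2)cc1` — 4000 nM
compound 2 `CCCC(Nc1ccc(-n2cnc(C(F)(F)F)c2)cc1)c1ccc(C(=O)NCCC(=O)O)cc1` — 4700 nM

In a functional assay on cells for antagonist activity at Glucagon receptor (Homo sapiens), read by cAMP accumulation, in the presence of a further agent that is not named here (a lower number here means a stronger inhibitor, a higher number a weaker inhibitor), compound 1 gives 4000 nM. In this assay compound 2 gives 4700 nM. These two numbers lie within the usual scatter of one another, so neither compound stands apart. Compound 3 `CCCC(Oc1ccc(-n2cc(C(F)(F)F)cn2)cc1)c1ccc(C(=O)NCCC(=O)O)cc1` has not been measured. It differs from compound 1 in one place: propyl in place of cyclopentyl on a saturated chain carbon bound to an aromatic carbon and an oxygen on an aromatic ring. Among the measured compounds shown here, no measured pair shows this change on its own, and compound 2, which carries a propyl group among other differences, gives a number close to that of compound 1. The step of a 1.3-fold higher number from compound 1 to compound 3 (0.10 log units; within the scatter) in this assay is expected to stay within the scatter. Compound 3 is expected to give 5000 nM, with a range from 2000 nM to 12000 nM.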

Compound 3, antagonist equilibrium constant: 5100 nM
For compound 3 the middle estimate is 1.0-fold (0.01 log units) below the measured one, and the stated range covers the measured number.
By their numbers in this assay, from the lowest: compounds 1, 2 and 3 (each within the scatter of the next).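

Swapping cyclopentyl for propyl on the saturated chain carbon bound to an aromatic carbon and an oxygen on an aromatic ring gives a 1.3-fold higher number from compound 1 to compound 3 (0.11 log units; within the scatter) in this assay. On this core, then, the five-membered ring is not needed to keep the number where it stands, and an open chain of fewer carbons serves alike. Nothing available here explains this result. On these data alone, what a longer chain, a methyl group or a ring carrying an amine would do at this carbon stays open. So does whether any group here can move the number beyond the scatter.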